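The source may report more compounds than this note shows. Statements on the series, on what has been measured and on what is new or still open speak of the compounds shown alone.

Compound 1 `Oc1ccc(-c2nc3cc(C(F)(F)F)ccc3[nH]2)cc1` is the starting point of this account. In an ADME assay on Vero cells (Chlorocebus sabaeus) for cytotoxicity (on this read-out lower numbers stand for higher toxicity in this test and higher numbers for lower toxicity in this test), compound 1 gives > 100000 nM, which is a limit of the assay and not a measured number. A second compound, compound 2 `COc1ccc(-c2nc3cc(C(C)=O)ccc3[nH]2)c(OC)c1`, carries the same core with other groups attached. In this assay compound 2 gives > 100000 nM, again a limit rather than a number. Where compound 1 stands among the known numbers is therefore plain: both values reported so far sit at the same limit, as shown by the limit of > 100000 nM in this assay, at which 2 of the 2 values shown sit, and no step between two measured compounds can be drawn from them.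

Compound 3 `O=C(CN1CCCC1)Nc1ccc(-c2nc3cc(C(F)(F)F)ccc3[nH]2)cc1` has not yet been measured. It differs from compound 1 by (((pyrrolidin-1-yl)methyl)carbonyl)amino in place of hydroxy on an aromatic carbon.

Because both known values sit at the limit of > 100000 nM in this assay, at which 2 of the 2 values shown sit, the step expected in this assay is a number no higher from compound 1 to compound 3 (the limit leaves the size open), that is, none beyond the usual scatter of repeated measurements. Compound 3 is thus estimated to give about 100000 nM, with a range from 30000 nM to 300000 nM, and the reported result may well be a limit again.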

Compound 3, half-maximal cytotoxic concentration: > 100000 nM
Compound 3 gave a limit, no number (the forecaster's own chance of this, stated with the estimate: 65%); the middle value lies on the limit itself.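

In this assay compound 3 gives > 100000 nM, a limit of the assay and not a number. Compound 1 also sits at a limit, so no step from compound 1 to compound 3 can be read: the limit of > 100000 nM in this assay, at which 3 of the 3 values shown sit.

The compounds shown leave open what number each would give, and whether (((pyrrolidin-1-yl)methyl)carbonyl)amino in place of hydroxy changes the read-out at all.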